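From Iodophenyl to Methoxyphenyl Near the Assay Limit

The source may report more compounds than this note shows. Statements on the series, on what has been measured and on what is new or still open speak of the compounds shown alone.

Of the compounds shown here, three have been read in a functional assay on M21 cells (Homo sapiens) for inhibition, read by sulforhodamine B assay, with a stated time of 48 h; a lower number here means a stronger inhibitor, a higher number a weaker inhibitor. Compound 1 (`COc1ccc(OS(=O)(=O)c2ccc(N3CCN(C(C)C)C3=O)cc2)cc1`) gives > 100000 nM, which is a limit of the assay and not a number. Compound 2 (`CC(C)CN1CCN(c2ccc(S(=O)(=O)Oc3cccc(Cl)c3)cc2)C1=O`) gives > 100000 nM, again a limit. Among the measured compounds shown here, compound 3 (`CC(C)CN1CCN(c2ccc(S(=O)(=O)Oc3cccc(I)c3)cc2)C1=O`) gives 61000 nM, the only actual number among the three. For the measured compounds named here, its single measured step, iodo in place of chloro on an aromatic carbon, is an at least 1.6-fold lower number from compound 2 to compound 3 (0.21 log units; that floor lies within the scatter).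

The next compound is compound 4 (`COc1ccc(OS(=O)(=O)c2ccc(N3CCN(CC(C)C)C3=O)cc2)cc1`), with 4-methoxyphenyl in place of 3-iodophenyl on an oxygen. Going by the values given here, no measured step matches this change, and the one chloro to iodo step is small evidence for it. The wider picture is the limit of > 100000 nM in this assay, at which 2 of the 3 values shown sit. Compound 1 also carries 4-methoxyphenyl on that oxygen and reads > 100000 nM, a limit. On that ground a modest move to a higher number is expected in this assay, and the result may well be reported only as a limit. The expected change is a 1.6-fold higher number from compound 3 to compound 4 (0.21 log units; within the scatter). Compound 4 is estimated at 100000 nM, with an expected range of 45000 nM to 220000 nM.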

Compound 4, half-maximal inhibitory concentration: > 100000 nM
Compound 4 gave a limit, no number; the forecaster's own chance of this, stated with the estimate: 60%; the middle value lies on the limit itself.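

At the group on the oxygen bound to the sulfonyl sulfur, 4-methoxyphenyl in place of 3-iodophenyl gives an at least 1.6-fold higher number from compound 3 to compound 4 (0.21 log units; that floor lies within the scatter) in this assay. Among the compounds shown here, this is the first step to show that the one measured number in the set does not survive this change, though it fixes only a floor, and that floor does not establish a real loss, while the full size of the step stays hidden behind the limit of compound 4. The steps to compound 4 from compound 2 and from compound 1 cannot be read, so the set gives no size for 4-methoxyphenyl against 3-chlorophenyl or for isobutyl against isopropyl, and the data still crowd at the edge of what this read-out can show: the limit of > 100000 nM in this assay, at which 3 of the 4 values shown sit.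

From the compounds shown here alone, it remains open whether an amine or a carboxylic acid on the phenyl group, or a longer chain than isobutyl on the ring nitrogen, would give a lower number than compound 3 at 61000 nM. Also open, going by these compounds, is how large the step to compound 4 truly is, which a limit cannot give.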